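Ring replacement on the double-bonded ring carbon of the core

A few compounds are considered here, and "the series" means these few. Any claim that something is new, unique, unknown or untested is made for them only; others in the source may bear on it.

Going by the values given here, compound 1 `C[C@@H](O[C@H]1CN2C(=O)C=C(c3ccc(C#N)cc3)CC2[C@@H]1c1ccc(F)cc1)c1cc(C(F)(F)F)cc(C(F)(F)F)c1` gives 1.8 nM in an assay on CHO cells for displacement of a labelled ligand from Substance-P receptor (Homo sapiens) (on this read-out higher numbers stand for weaker inhibition and lower numbers for stronger inhibition), the highest of the three numbers measured so far. Its nearest neighbour is compound 2 `C[C@@H](O[C@H]1CN2C(=O)C=C(c3ccc(NS(C)(=O)=O)cc3)CC2[C@@H]1c1ccc(F)cc1)c1cc(C(F)(F)F)cc(C(F)(F)F)c1`, which gives 1 nM in this assay; its furthest is compound 3 `C[C@@H](O[C@H]1CN2C(=O)C=C(c3ccc[n+]([O-])c3)CC2[C@@H]1c1ccc(F)cc1)c1cc(C(F)(F)F)cc(C(F)(F)F)c1`, which gives 0.15 nM in this assay. The step of a 1.8-fold lower number from compound 1 to compound 2 (0.26 log units; within the scatter) stays within the scatter, whereas a 12-fold lower number from compound 1 to compound 3 (1.08 log units; beyond the scatter) and a 6.7-fold lower number from compound 2 to compound 3 (0.82 log units; beyond the scatter) lie beyond it.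

Compound 4 `C[C@@H](O[C@H]1CN2C(=O)C=C(c3cnn(Cc4ccccc4)c3)CC2[C@@H]1c1ccc(F)cc1)c1cc(C(F)(F)F)cc(C(F)(F)F)c1` differs from compound 1 in one place: 1-benzyl-1H-pyrazol-4-yl in place of 4-cyanophenyl on a double-bonded ring carbon. Both measured steps from compound 1 bear on this change, since each swaps the group on the same double-bonded ring carbon, but neither brings in a 1-benzyl-1H-pyrazol-4-yl group. The one replacement of the aromatic ring itself, a 12-fold lower number from compound 1 to compound 3 (1.08 log units; beyond the scatter), went to a lower number; the replacement of a substituent, a 1.8-fold lower number from compound 1 to compound 2 (0.26 log units; within the scatter), did not move beyond the scatter. Compound 4 is therefore expected to give 3 nM in this assay, with a range of 0.6 nM to 15 nM. For compound 4 the expected step is a 1.7-fold higher number from compound 1 to compound 4 (0.22 log units; within the scatter), with no direction beyond the scatter claimed.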

Compound 4, half-maximal inhibitory concentration: 1.9 nM
Compound 4: middle estimate off by 1.6-fold (0.20 log units), on the high side, and the stated range covers the measured number.
By their numbers in this assay, from the lowest: compound 3; then compounds 2, 1 and 4 (each within the scatter of the next).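

In this assay, 1-benzyl-1H-pyrazol-4-yl on the double-bonded ring carbon, at 12 heavy atoms against 8 for 4-cyanophenyl, gives a 1.1-fold higher number from compound 1 to compound 4 (0.02 log units; within the scatter), and the comparison with the 4-(methanesulfonamido)phenyl group gives a 1.9-fold higher number from compound 2 to compound 4 (0.28 log units; within the scatter), so these three quite different groups cannot be told apart at this position. Against the group of compound 3 the picture differs, with a 13-fold higher number from compound 3 to compound 4 (1.10 log units; beyond the scatter), which shows that replacing the carbon-only aromatic ring on this carbon does not by itself bring the low number of compound 3. Nothing measured here gives a reason for that gap.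

Still open, going by these compounds, is what the benzyl part contributes, which a 1-methyl group on the same pyrazole would help to separate from the ring itself. Also open, on these data alone, is whether an amine or a carboxylic acid on the aromatic ring at this carbon would reach the number of compound 3.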